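The source may hold more compounds than are shown below. What is called first, only, known or untested is meant among the compounds shown, and "the series" means these compounds.

Compound 1 `O=C(Nc1cccc(-n2cc(-c3ccncc3)c(-c3cc(O)cc(Cl)c3)n2)c1)Nc1ccc(Cl)c(C(F)(F)F)c1` and compound 2 `COc1cc(Cl)cc(-c2nn(-c3cccc(NC(=O)Nc4ccc(Cl)c(C(F)(F)F)c4)c3)cc2-c2ccncc2)c1` are built on one shared core and differ in a single spot: methyl in place of hydrogen on an oxygen on an aromatic ring. In a functional assay on NCI-H226 cells (Homo sapiens) for inhibition, read by sulforhodamine B assay, with a stated time of 48 h, tested at 10 uM (a lower number here means a stronger effect, a higher number a weaker effect of the compound at the concentration tested), compound 1 gives 41.2%, whereas compound 2 gives -2.82%, which makes the step of a number 44 percentage points lower from compound 1 to compound 2 (beyond the scatter). Compound 3 `O=C(Nc1cccc(-n2cc(-c3ccncc3)c(-c3cc(O)cc(Cl)c3)n2)c1)c1cc(C(F)(F)F)cc(C(F)(F)F)c1` rests on a different core; how the two cores differ is not broken down here. In this assay compound 3 gives 96%, the highest of the three numbers. Compound 4 `COc1cc(Cl)cc(-c2nn(-c3cccc(NC(=O)c4cc(C(F)(F)F)cc(C(F)(F)F)c4)c3)cc2-c2ccncc2)c1` carries the same change as before, now on the core of compound 3: methyl in place of hydrogen on an oxygen on an aromatic ring. The place of the change reads the same in both pairs, so this is the same change. Its effect has been seen only once and on another core, so its size on this core is uncertain. The expected step is a number 38 percentage points lower from compound 3 to compound 4 (beyond the scatter), which rests on the earlier step of a number 44 percentage points lower from compound 1 to compound 2 (beyond the scatter). Compound 4 is therefore estimated at 58% in this assay, with an expected range from 20% to 98%.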

Compound 4, a percentage reported as activity, at one concentration (the size of the read-out at that concentration, not a potency): 76%
Compound 4: the middle estimate sits 18 percentage points below what was measured; the range from low to high includes it.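

Replacing hydroxy with methoxy on the second core again moves the read-out in this assay the same way, giving a number 20 percentage points lower from compound 3 to compound 4 (beyond the scatter), so on these two cores the direction of the change carries over. The size of the step does not carry over, and the two steps differ by more than repeated measurements would explain: the same change on two cores in this assay, a number 44 percentage points lower (beyond the scatter) from compound 1 to compound 2 and a number 20 percentage points lower (beyond the scatter) from compound 3 to compound 4, 24 percentage points apart, beyond the scatter of two such steps. Two pairs show that the direction can hold while the size depends on the core, but they do not make a rule for other cores, and these numbers alone do not explain why the size differs.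

Still open, from the compounds shown here alone, is whether the step would keep its direction on a further core, and how much of it belongs to the methyl group itself rather than to the replacement of the hydroxy hydrogen. An ethyl group or a longer chain on that oxygen, or an amine in place of the hydroxy, would help to separate these two readings.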